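The compounds below may be only part of what the source reports. "The series", "measured", "known", "first", "only" and "open" are said of these compounds alone.

Among the compounds with values here, in a physicochemical assay for solubility, read by HPLC (on this read-out lower numbers stand for lower solubility and higher numbers for higher solubility), compound 2 `O=c1nc(N2CCN(CC3CCCCC3)CC2)sc2c([N+](=O)[O-])cc(C(F)(F)F)cc12` stands highest of the two numbers so far at 9.07 ug/mL, while compound 1 `O=C(CC1CCCCC1)N1CCN(c2nc(=O)c3cc(C(F)(F)F)cc([N+](=O)[O-])c3s2)CC1` gives 0.12 ug/mL. Compound 3 `CCC(C)C(=O)N1CCN(c2nc(=O)c3cc(C(F)(F)F)cc([N+](=O)[O-])c3s2)CC1` has (sec-butyl)carbonyl in place of cyclohexylmethyl on an amine nitrogen in a ring, and differs from compound 2 as follows: (sec-butyl)carbonyl in place of cyclohexylmethyl on an amine nitrogen in a ring. Within the data shown here, only one measured step bears on this change: a 76-fold higher number from compound 1 to compound 2 (1.88 log units; beyond the scatter), a large step beyond the scatter, made by replacing (cyclohexylmethyl)carbonyl with cyclohexylmethyl at that nitrogen. Compound 3 restores a carbonyl there, so the reverse direction of that step, towards a lower number, is expected in this assay. Among the measured compounds shown here, the six-membered non-aromatic ring of carbon only also leaves, and no measured step isolates that loss, so the expected step may be smaller than the measured one. The expected change is a 15-fold lower number from compound 2 to compound 3 (1.18 log units; beyond the scatter). The estimate for compound 3 is 0.6 ug/mL, with an expected range of 0.15 ug/mL to 3 ug/mL.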

Compound 3, solubility: 104 ug/mL
Compound 3: the middle estimate sits 170-fold (2.24 log units) below what was measured; the whole stated range lies below it.
By their numbers in this assay, from the lowest: compound 1; then compound 2; then compound 3.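

In this assay, a carbonyl on the amine nitrogen in the ring does not by itself go with a low number: an 11-fold higher number from compound 2 to compound 3 (1.06 log units; beyond the scatter) runs in the same direction as a 76-fold higher number from compound 1 to compound 2 (1.88 log units; beyond the scatter) even though the carbonyl is present in compound 3 and absent from compound 2. With the carbonyl held in place, sec-butyl in place of cyclohexylmethyl on the carbonyl carbon gives an 870-fold higher number from compound 1 to compound 3 (2.94 log units; beyond the scatter) and so shows that the read-out at this nitrogen depends on what the carbonyl bears, not only on whether a carbonyl is there. Nothing available explains either step.

Going by these compounds, whether the loss of the ring or the branching of the chain matters more stays open. A straight butyl chain or a cyclopentyl group on the carbonyl carbon would separate the two.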